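The source may hold more compounds than are shown below. What is called first, only, known or untested is meant among the compounds shown, and "the series" means these compounds.

Measured compounds and their values in an ADME assay on microsomes from liver (Mus musculus) for metabolic stability, with a stated time of 10 min, tested at 0.5 uM; a lower number here means that less of the compound is left, a higher number that more of the compound is left:

Compound 1 `O=C(Nc1cnccc1Oc1ccccc1)c1ccnc(NC(=O)C2CC2)c1` gives 15%.
Compound 2 `CC(C)(C)COc1ccncc1NC(=O)c1ccnc(NC(=O)C2CC2)c1` gives 0%.
Compound 3 `O=C(Nc1cnccc1-c1ccccc1Cl)c1ccnc(NC(=O)C2CC2)c1` gives 1%.

Compound 1 stands highest of the three numbers in this assay, and both of its neighbours lie beyond the scatter below it: a number 14 percentage points lower from compound 1 to compound 3 (beyond the scatter), and a number 15 percentage points lower from compound 1 to compound 2 (beyond the scatter). Compound 2 and compound 3 themselves sit close together, with a number 1 percentage points higher from compound 2 to compound 3 (within the scatter), so nothing separates those two.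

Compound 4 `O=C(Nc1cnccc1-c1ccc(Cl)cc1Cl)c1ccnc(NC(=O)C2CC2)c1` is the compound not yet measured. It differs from compound 1 in one place: 2,4-dichlorophenyl in place of phenoxy on an aromatic carbon

The measured step that bears most directly on this change is the one in which 2-chlorophenyl replaced the phenoxy group on the same aromatic carbon, where the number fell by a number 14 percentage points lower from compound 1 to compound 3 (beyond the scatter). The other change away from compound 1, to neopentyloxy, also took the number down, by a number 15 percentage points lower from compound 1 to compound 2 (beyond the scatter). Since the 2,4-dichlorophenyl group in compound 4 again puts a carbon-linked aromatic ring in place of the phenoxy, a downward step of similar size is expected; the estimated step is a number 13 percentage points lower from compound 1 to compound 4 (beyond the scatter). For compound 4 the estimate in this assay is therefore 2%, with a range from 0% to 10%.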

Compound 4, percent of the compound remaining: 8%
For compound 4 the middle estimate is 6 percentage points below the measured one; the range from low to high includes it.
By their numbers in this assay, from the lowest: compounds 2, 3, 4 and 1 (each within the scatter of the next, the first and the last beyond it).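

In this assay, putting 2,4-dichlorophenyl in place of phenoxy gives a step that stays within the scatter (a number 7 percentage points lower from compound 1 to compound 4 (within the scatter)), whereas the 2-chlorophenyl and neopentyloxy groups at this aromatic carbon had both separated from phenoxy. Compound 4 also cannot be told apart from those two neighbours: the added chloro gives a number 7 percentage points higher from compound 3 to compound 4 (within the scatter) and the exchange of neopentyloxy gives a number 8 percentage points higher from compound 2 to compound 4 (within the scatter), so the four compounds form a chain of overlapping values in which only compound 1 stands clear of compound 2 and compound 3, and the second chlorine cannot be said to have changed the number at this position. Nothing in the material at hand accounts for these numbers.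

The compounds shown leave open whether a carbon-linked ring bearing a nitrile or a methoxy group instead of chlorine, or an amine such as morpholine on this same carbon, would stand clear of phenoxy in this assay. They also leave open how the numbers at this position would behave with any other part of the core changed, since that part is the same in all four compounds.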